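Adding a second chloro to the purine core of compound 2

This account rests on a few compounds, and the source may have more. Where it says the series, first, only, none or still open, it means among the compounds named here.

Compound 1 `ClCc1cccc(Cn2cnc3c(Cl)nc(Cl)nc32)c1` — in a functional assay on HCT-116 cells (Homo sapiens) for cytotoxicity, read by sulforhodamine B assay, with a stated time of 48 h (on this read-out higher numbers stand for weaker inhibition of growth and lower numbers for stronger inhibition of growth), compound 1 gives 3090 nM
Compound 2 `ClCc1ccccc1Cn1cnc2ncnc(Cl)c21` — in this assay compound 2 gives 4070 nM

Of these two numbers, compound 2 has the higher one, yet its distance from compound 1 lies within the usual scatter, so the two are not told apart. Compound 3 `ClCc1ccccc1Cn1cnc2nc(Cl)nc(Cl)c21` differs from compound 2 by chloro in place of hydrogen on an aromatic carbon. Compound 1, which also carries two chloro groups on the shared core, gives no hint of a large effect, so only a small step, if any, is expected. Compound 3 is estimated at 3000 nM (range 1200 nM to 7500 nM), a step of a 1.4-fold lower number from compound 2 to compound 3 (0.13 log units; within the scatter).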

Compound 3, concentration for total growth inhibition: 4070 nM
Compound 3: middle estimate off by 1.4-fold (0.13 log units), on the low side; low and high end bracket the measured number.
By their numbers in this assay, from the lowest: compounds 1, 2 and 3 (each within the scatter of the next).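

In this assay chloro in place of hydrogen on the aromatic carbon between two ring nitrogen atoms gives no change at the digits printed from compound 2 to compound 3 (within the scatter) and so leaves growth inhibition unchanged within the scatter. For the compounds shown here, this is the first comparison that isolates this position, as compounds 1 and 2 differ in more than one place. Nothing measured here accounts for this result. From the compounds shown here alone, whether an amine or a methoxy group at this carbon would also leave the number unchanged stays open.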